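This account rests on a few compounds, and the source may have more. Where it says the series, first, only, none or still open, it means among the compounds named here.

Three compounds share one core and differ only in the aromatic ring attached to an aromatic nitrogen of the five-membered ring. Compound 1 `CC1(C)[C@H]2CC[C@]1(C)N(Cc1cn(-c3cccc(Cl)c3)nn1)C(=O)C2` gives 260 nM in a functional assay on PANC-1 cells (Homo sapiens) for inhibition, read by MTT assay, with a stated time of 24 h; a higher number here means a weaker inhibitor, a lower number a stronger inhibitor. Compound 2 `CC1(C)[C@H]2CC[C@]1(C)N(Cc1cn(-c3ccc(Cl)cc3)nn1)C(=O)C2` gives 440 nM. Compound 3 `CC1(C)[C@H]2CC[C@]1(C)N(Cc1cn(-c3ccccc3O)nn1)C(=O)C2` gives 230 nM, and its gaps to compound 1 and compound 2 are both within the scatter, so the three compounds cannot be separated on these numbers.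

Compound 4 `COc1ccc(-n2cc(CN3C(=O)C[C@@H]4CC[C@@]3(C)C4(C)C)nn2)cc1` is the next step from compound 3: 4-methoxyphenyl in place of 2-hydroxyphenyl on an aromatic nitrogen. Every change seen so far at this position left the number essentially unmoved: a 1.7-fold higher number from compound 1 to compound 2 (0.23 log units; within the scatter), a 1.1-fold lower number from compound 1 to compound 3 (0.05 log units; within the scatter), and a 1.9-fold lower number from compound 2 to compound 3 (0.28 log units; within the scatter). Among the compounds with values here, no measured step involves a methoxy group, so the expectation rests only on the observation that swapping substituents on this ring has so far produced nothing beyond the scatter. Compound 4 is therefore expected to stay close to compound 3, with a step of about a 1.3-fold higher number from compound 3 to compound 4 (0.12 log units; within the scatter). The estimate for compound 4 is 300 nM, with a likely range from 130 nM to 700 nM.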

Compound 4, half-maximal inhibitory concentration: 330 nM
The estimate for compound 4 lay 1.1-fold (0.04 log units) below the measured number, within the range that was stated.
By their numbers in this assay, from the lowest: compounds 3, 1, 4 and 2 (each within the scatter of the next).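

In this assay, the swap from 2-hydroxyphenyl to 4-methoxyphenyl exchanges a group that has a hydrogen-bond donor for one that has none, yet it gives a 1.4-fold higher number from compound 3 to compound 4 (0.16 log units; within the scatter). Two further comparisons bring methoxy into direct contrast with chloro: methoxy in place of chloro on an aromatic carbon gives a 1.3-fold lower number from compound 2 to compound 4 (0.12 log units; within the scatter), and 4-methoxyphenyl in place of 3-chlorophenyl gives a 1.3-fold higher number from compound 1 to compound 4 (0.10 log units; within the scatter). The range of substituents at this position now includes hydroxy, chloro and methoxy without any step beyond the scatter, and no supporting information is available to explain this result.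

As far as these compounds go, it remains open whether an amine or a carboxylic acid on this aromatic ring, or a longer chain in place of the ring, would move the number beyond the scatter. The core is the same in all four compounds, so the effect of changing it is also unknown.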